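A few compounds are considered here, and "the series" means these few. Any claim that something is new, unique, unknown or untested is made for them only; others in the source may bear on it.

Compound 1 `COc1ccc(/C=C2\CN(C(=O)CCSCCS)C/C(=C\c3ccc(OC)cc3)C2=O)cc1` is the starting point of this account. In a functional assay on HSC-2 cells (Homo sapiens) for cytotoxicity, read by MTT assay, with a stated time of 48 h (on this read-out higher numbers stand for lower toxicity in this test and lower numbers for higher toxicity in this test), compound 1 gives 3370 nM, the lowest of the three numbers recorded. Compound 2 `O=C1/C(=C/c2ccc(Cl)cc2)CN(C(=O)CCSCCS(=O)(=O)O)C/C1=C\c1ccc(Cl)cc1` gives 29700 nM in this assay, and compound 3 `O=C1/C(=C/c2ccccc2)CN(C(=O)CCSCCS(=O)(=O)O)C/C1=C\c1ccccc1` gives 154000 nM in this assay; both gaps from compound 1 lie beyond the scatter. Within the data shown here, no two of these three compounds differ in a single place, so no single-change step among them is available to guide the next move. Compound 4 `COc1ccc(/C=C2\CN(C(=O)CCSCCO)C/C(=C\c3ccc(OC)cc3)C2=O)cc1` is not yet measured. It differs from compound 1 in one place: hydroxy in place of sulfanyl on a saturated chain carbon, two bonds along the chain from a sulfur. Among the measured compounds shown here, the measured compounds offer no direct precedent for this exchange, as compound 2 and compound 3 differ from compound 1 elsewhere as well. The step from compound 1 to compound 4 is expected to be a small rise in the number, a 1.8-fold higher number from compound 1 to compound 4 (0.25 log units; within the scatter), possibly not beyond the scatter. Compound 4 is therefore expected to give 6000 nM in this assay, with a range from 1500 nM to 25000 nM.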

Compound 4, half-maximal cytotoxic concentration: 2670 nM
For compound 4 the middle estimate is 2.2-fold (0.35 log units) above the measured one; measured number inside the range.
By their numbers in this assay, from the lowest: compounds 4 and 1 (each within the scatter of the next); then compound 2; then compound 3.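

Under this assay the exchange of hydroxy for sulfanyl on a saturated chain carbon, two bonds along the chain from a sulfur, gives a 1.3-fold lower number from compound 1 to compound 4 (0.10 log units; within the scatter) and so provides the first single-change step among these compounds. At this place the read-out does not separate the two groups, and the sulfanyl of compound 1 is therefore not needed to keep the number within the scatter of that seen for compound 1. No measured property on hand bears on this result.

The compounds shown leave open whether an amine or a carboxylic acid at this same place would also stay within the scatter of compound 1. They also leave open whether a longer chain ending in hydroxy would read alike on the core of compound 4.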